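Cytotoxicity limits on the step from compound 1 to compound 4

The compounds below may be only part of what the source reports. "The series", "measured", "known", "first", "only" and "open" are said of these compounds alone.

In an ADME assay on Vero cells (Chlorocebus sabaeus) for cytotoxicity (a lower number here means that less compound is tolerated, a higher number that more compound is tolerated), compound 1 `CN1CCN(CC(=O)Nc2ccc(-c3nc4cc(C(F)(F)F)ccc4n3C)cc2)CC1` reports only a limit of the assay, > 100000 nM, and not a number. Compound 2 `Nc1ccc(-c2nc3cc(Cl)c(Cl)cc3[nH]2)cc1` likewise gives only a limit, >= 100000 nM. Compound 3 `O=C(O)CCC(=O)Nc1ccc(-c2nc3cc(C(F)(F)F)ccc3[nH]2)cc1` also stands at a limit, > 100000 nM. Going by the values given here, two of the three values sit at the limit of > 100000 nM in this assay, at which 2 of the 3 values shown sit, and one at the limit of >= 100000 nM in this assay, at which 1 of the 3 values shown sits; no measured step between these compounds exists, so the series offers nothing to rank.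

Compound 4 `CCC(=O)Nc1ccc(-c2nc3cc(C(F)(F)F)ccc3n2C)cc1` is still to be measured in this assay. It differs from compound 1 by methyl in place of 4-methylpiperazin-1-yl on a saturated chain carbon bound to a carbonyl carbon. Three compounds that differ at several places all report only limits, so no change beyond the scatter is expected here. The expected step is a number no higher from compound 1 to compound 4 (the limit leaves the size open). Compound 4 is expected to give 100000 nM, with a range from 50000 nM to 200000 nM, most likely reported again as a limit.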

Compound 4, half-maximal cytotoxic concentration: > 100000 nM
Compound 4 gave a limit, no number; the forecaster's own chance of this, stated with the estimate: 85%; the middle value lies on the limit itself.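

No step from compound 1 to compound 4 can be read in this assay, as both report only a limit: the limit of > 100000 nM in this assay, at which 3 of the 4 values shown sit.

The compounds shown leave open whether methyl in place of 4-methylpiperazin-1-yl changes the tolerated concentration at all.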